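Replacing a Nitrile Aryl Group on a Shared Core

The source may hold more compounds than are shown below. What is called first, only, known or untested is meant among the compounds shown, and "the series" means these compounds.

Three measured compounds share one core and differ only in the aryl group on it. Compound 1 `COc1cc(-c2ccnc3cc(-c4ccc(C)c(C)c4)nn23)cc(OC)c1OC` carries 3,4-dimethylphenyl, and in a functional assay on A549 cells (Homo sapiens) for inhibition, read by CCK-8 assay, with a stated time of 48 h (on this read-out lower numbers stand for stronger inhibition and higher numbers for weaker inhibition), compound 1 gives 272 nM. Compound 3 `COc1ccc(-c2cc3nccc(-c4cc(OC)c(OC)c(OC)c4)n3n2)cc1F` carries 3-fluoro-4-methoxyphenyl, and in this assay compound 3 gives 545 nM. Compound 2 `COc1cc(-c2ccnc3cc(-c4cccc(C#N)c4)nn23)cc(OC)c1OC` carries 3-cyanophenyl; in this assay compound 2 gives > 10000 nM, which is a limit of the assay and not a number. Compound 2 thus sits at the weak end of the three, at the limit of > 10000 nM in this assay, at which 1 of the 3 values shown sits. Both steps that involve it are large: an at least 36-fold higher number from compound 1 to compound 2 (1.56 log units; beyond the scatter) and an at least 18-fold lower number from compound 2 to compound 3 (1.26 log units; beyond the scatter).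

Compound 4 `COc1ccc(-c2cc3nccc(-c4cc(OC)c(OC)c(OC)c4)n3n2)cc1N` has not yet been measured. It differs from compound 2 by 3-amino-4-methoxyphenyl in place of 3-cyanophenyl on an aromatic carbon. The nearest measured step, from compound 2 to compound 3, also removes 3-cyanophenyl and brings in a 4-methoxy-bearing aryl, and it was an at least 18-fold lower number from compound 2 to compound 3 (1.26 log units; beyond the scatter). A large decrease of similar size is therefore expected here, an at least 14-fold lower number from compound 2 to compound 4 (1.15 log units; beyond the scatter). Compound 4 is estimated at 700 nM, within 200 nM to 3000 nM.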

Compound 4, half-maximal inhibitory concentration: 138 nM
Beside the measured number, compound 4's estimate is 5.1-fold (0.71 log units) above it, and the stated range ends above it.
By their numbers in this assay, from the lowest: compounds 4, 1 and 3 (each within the scatter of the next, the first and the last beyond it). At a limit, above all of these: compound 2.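

Keeping the 4-methoxy group, amino in place of fluoro on this aryl group gives a 3.9-fold lower number from compound 3 to compound 4 (0.60 log units; beyond the scatter), so a single small change here moves the number beyond the scatter, which no earlier pair with a 4-methoxy-bearing aryl group had shown. On the aromatic carbon of the shared core, 3-amino-4-methoxyphenyl in place of 3-cyanophenyl gives an at least 72-fold lower number from compound 2 to compound 4 (1.86 log units; beyond the scatter), whereas the same group in place of 3,4-dimethylphenyl gives a 2.0-fold lower number from compound 1 to compound 4 (0.29 log units; within the scatter), so these last two aryl groups cannot be ranked. Compound 2 stays at a limit of the assay, so the first of those two steps is a bound and not an exact size: the limit of > 10000 nM in this assay, at which 1 of the 4 values shown sits.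

The compounds shown leave open whether a hydroxyl, a methylamino or an acetamide group could stand in place of the amino group with a similar result. They also leave open whether the amino group would give a similar number without the 4-methoxy group.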